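Phenyl-to-hydrogen step on the ring nitrogen of compound 1

A few compounds are considered here, and "the series" means these few. Any claim that something is new, unique, unknown or untested is made for them only; others in the source may bear on it.

Measured so far in a functional assay on NCI-H460 cells (Homo sapiens) for antiproliferative activity, read by sulforhodamine B assay, with a stated time of 72 h; a lower number here means a stronger inhibitor, a higher number a weaker inhibitor:
- compound 1, `O=C1CS/C(=N/Nc2nncc3ccccc23)N1c1ccccc1`, gives 30 nM
- compound 2, `C(=C/c1ccccc1)\C(=N\Nc1nncc2ccccc12)c1ccccc1`, gives 5.7 nM
- compound 3, `S=C(NNc1nncc2ccccc12)Nc1ccccc1`, gives 16 nM

Compound 1 stands at the highest of the three numbers. Compound 3 sits nearest to it, and the gap between the two lies within the scatter, so no order between compound 1 and compound 3 is claimed. Compound 2 lies furthest from compound 1, with a lower number that is beyond the scatter. Among the measured compounds shown here, none of the three measured compounds differ from each other in a single place, so no measured step is available to calibrate the change considered here.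

The unmeasured compound 4, `O=C1CS/C(=N/Nc2nncc3ccccc23)N1`, differs from compound 1 in one place:

hydrogen in place of phenyl on an amide-type nitrogen in a ring

With no measured step of this kind in this assay, the size of the expected change rests on judgment alone. The expectation is a move toward a higher number, beyond the scatter: a 3.3-fold higher number from compound 1 to compound 4 (0.52 log units; beyond the scatter). For compound 4 the estimated value in this assay is 100 nM, with a range from 30 nM to 400 nM.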

Compound 4, half-maximal inhibitory concentration: 19 nM
Estimate against measurement, compound 4: 5.3-fold (0.72 log units) above; measured number below the stated range.
By their numbers in this assay, from the lowest: compound 2; then compounds 3, 4 and 1 (each within the scatter of the next).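

In this assay, hydrogen in place of phenyl on the amide-type nitrogen in the ring gives a 1.6-fold lower number from compound 1 to compound 4 (0.20 log units; within the scatter), the first single-place step measured in this series, and it lies within the scatter, so no order between the two compounds is claimed. The position therefore does not depend on the phenyl for activity at this level: without that aromatic ring, compound 4 still gives 19 nM, so the whole group can leave with no change that stands out from the scatter. No measured evidence bears on this result, and the data cannot say why the step stays this small.

Only phenyl and hydrogen are shown on this nitrogen, so it remains open whether methyl, a longer chain, or a chain carrying an amine or a carboxylic acid would leave the number unchanged or move it beyond the scatter. A phenyl carrying a chlorine or a methoxy group is also absent from the compounds shown, so the response to changes on that ring cannot be read.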